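The source may report more compounds than this note shows. Statements on the series, on what has been measured and on what is new or still open speak of the compounds shown alone.

Measured so far:
Compound 1, `COC(=O)c1ccc(CCCCCCC(=O)c2ncc(-c3ccccn3)o2)cc1`, in an assay for inhibition of Fatty-acid amide hydrolase 1 (Rattus norvegicus); a lower number here means a stronger inhibitor, a higher number a weaker inhibitor: compound 1 gives 1.5 nM.
Compound 2, `Nc1cccc(CCCCCCC(=O)c2ncc(-c3ccccn3)o2)c1`: in this assay compound 2 gives 30 nM.

Of the two measured compounds, compound 1 has the lower number in this assay, and compound 2 stands well above it, a gap that lies beyond the usual scatter. The two differ in more than one place, so the gap cannot be tied to a single change.

Compound 3, `CS(=O)(=O)c1ccc(CCCCCCC(=O)c2ncc(-c3ccccn3)o2)cc1`, is the next compound to be measured in this assay. It keeps the whole of compound 1 apart from one change: methylsulfonyl in place of methoxycarbonyl on an aromatic carbon. Both the group that leaves and the group that enters are small and carry no donor. Among the measured compounds shown here, no measured pair shows this exact exchange, so the expectation rests on the closeness of the two groups rather than on a known step. The step from compound 1 to compound 3 is expected to be small, a 2.0-fold higher number from compound 1 to compound 3 (0.30 log units; within the scatter), likely within the scatter or a little toward weaker inhibition. Compound 3 is therefore estimated at 3 nM, with a range from 1 nM to 12 nM.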

Compound 3, inhibition constant: 19 nM
For compound 3 the middle estimate is 6.3-fold (0.80 log units) below the measured one; the whole stated range lies below it.
By their numbers in this assay, from the lowest: compound 1; then compounds 3 and 2 (each within the scatter of the next).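

In this assay, putting methylsulfonyl in place of methoxycarbonyl on this aromatic carbon gives a 13-fold higher number from compound 1 to compound 3 (1.10 log units; beyond the scatter) and so shows that this position is sensitive to the group it carries. The two groups have the same heavy-atom count, the same hydrogen-bond donor and acceptor counts and no net charge, so these counts alone do not predict the result here; the groups differ in that sulfur enters and in their double bonds outside aromatic rings. Nothing available here accounts for the size of this step.

Still open, going by these compounds, is how a carboxylic acid, an amide or a nitrile at this same place would compare with methoxycarbonyl. Also open, on these data alone, is whether this exchange would give a step of similar size on a compound with a longer chain.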